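Swapping a Thiophene for a Pyridine in Compound 1

The source may report more compounds than this note shows. Statements on the series, on what has been measured and on what is new or still open speak of the compounds shown alone.

Compound 1 `CCN(c1ccc(C#N)c(Cl)c1)c1cc(-c2cccs2)ccc1C` carries a thiophen-2-yl group on its core, and in a functional assay on PC-3 cells (Homo sapiens) for antiproliferative activity, read by CCK-8 assay, with a stated time of 6 days (on this read-out higher numbers stand for weaker inhibition and lower numbers for stronger inhibition), compound 1 reaches only > 30000 nM, which is a limit of the assay rather than a measured number. Two related compounds have numbers. Compound 2 `CCN(c1ccc(C#N)c(Cl)c1)c1cc(-c2cnc3ccccc3c2)ccc1C` carries a quinolin-3-yl group instead and gives 3570 nM in this assay. Compound 3 `N#Cc1ccc(N2CCCc3c(-c4ccncc4)cccc32)cc1C(F)(F)F`, built on a different core but bearing a pyridin-4-yl group, gives 28700 nM in this assay. Compound 4 `CCN(c1ccc(C#N)c(Cl)c1)c1cc(-c2ccncc2)ccc1C` is still unmeasured; it differs from compound 1 by pyridin-4-yl in place of thiophen-2-yl on an aromatic carbon. With compound 1 sitting at the limit, the comparison can only be one-sided. The step is expected to be modest, an at least 2.0-fold lower number from compound 1 to compound 4 (0.30 log units; that floor lies within the scatter), toward somewhat stronger inhibition at best, or none beyond the scatter. Compound 4 is estimated at 15000 nM, within a range of 4000 nM to 60000 nM, an expectation resting on compound 3 giving 28700 nM with the same pyridin-4-yl group.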

Compound 4, half-maximal inhibitory concentration: 3580 nM
The estimate for compound 4 lay 4.2-fold (0.62 log units) above the measured number, outside the stated range (below it).
By their numbers in this assay, from the lowest: compounds 2 and 4 (each within the scatter of the next); then compound 3. At a limit, above all of these: compound 1.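

In this assay, pyridin-4-yl in place of thiophen-2-yl on the shared core brings an at least 8.3-fold lower number from compound 1 to compound 4 (0.92 log units; beyond the scatter), so the group at this position clearly affects the read-out. Compound 4 and compound 2 lie within the scatter of each other, so the single ring of pyridin-4-yl cannot be told apart here from the larger quinolin-3-yl group. The true size of the step stays unknown because compound 1 gives only a limit of the assay, not a number: the limit of > 30000 nM in this assay, at which 1 of the 4 values shown sits.

A plain phenyl group or a pyridin-3-yl group at this position would show whether the ring nitrogen of pyridin-4-yl is what counts. Going by these compounds, how an amine or a carboxylic acid placed here would fare also remains open.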